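A 3,5-dimethylphenyl group enters at the ring amine nitrogen

The compounds below may be only part of what the source reports. "The series", "measured", "known", "first", "only" and "open" are said of these compounds alone.

Compound 1 `Cc1nc(-c2ccccc2)c(C(=O)N2CCN(c3cccc(C)c3C)CC2)o1` gives 35 nM as its value
Compound 2 `Cc1nc(-c2ccccc2)c(C(=O)N2CCN(c3ccccc3C(F)(F)F)CC2)o1` gives 120 nM as its value

Going by the values given here, in a functional assay on HL-60 cells (Homo sapiens) for inhibition, read by MTT assay, with a stated time of 72 h (on this read-out lower numbers stand for stronger inhibition and higher numbers for weaker inhibition), compound 2 gives 120 nM and holds the higher of the two numbers, with compound 1 as its only neighbour. Compound 3 `Cc1cc(C)cc(N2CCN(C(=O)c3oc(C)nc3-c3ccccc3)CC2)c1` differs from compound 2 by 3,5-dimethylphenyl in place of 2-(trifluoromethyl)phenyl on an amine nitrogen in a ring and so has 3,5-dimethylphenyl in place of 2-(trifluoromethyl)phenyl on an amine nitrogen in a ring. Among the compounds with values here, one measured step bears on this: a 3.4-fold higher number from compound 1 to compound 2 (0.54 log units; beyond the scatter) is modest and beyond the scatter, and it came with 2-(trifluoromethyl)phenyl replacing 2,3-dimethylphenyl. Compound 3 again carries a dimethylphenyl group, but no 3,5-dimethylphenyl compound has been measured, so a step of similar or smaller size towards a lower number is expected in this assay for now. The expected step is a 2.0-fold lower number from compound 2 to compound 3 (0.30 log units; within the scatter) in this estimate. Compound 3 is estimated at 60 nM with an expected range from 20 nM to 170 nM in this assay.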

Compound 3, half-maximal inhibitory concentration: 34.5 nM
Compound 3: the middle estimate sits 1.7-fold (0.24 log units) above what was measured, and the stated range covers the measured number.
By their numbers in this assay, from the lowest: compounds 3 and 1 (each within the scatter of the next); then compound 2.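

In this assay, the step of a 3.5-fold lower number from compound 2 to compound 3 (0.54 log units; beyond the scatter) is beyond the scatter and comes with 3,5-dimethylphenyl in place of 2-(trifluoromethyl)phenyl on an amine nitrogen in a ring, so among the three compounds, the one carrying 2-(trifluoromethyl)phenyl stands apart from both dimethylphenyl compounds. The step of a 1.0-fold lower number from compound 1 to compound 3 (0.01 log units; within the scatter) lies within the scatter, so 2,3-dimethylphenyl and 3,5-dimethylphenyl cannot be told apart at this position in this assay. Nothing available explains why these groups read as they do.

The compounds shown leave open how a phenyl group bearing a methoxy group, an amine or a carboxylic acid would read on this ring nitrogen. They also leave open whether a single methyl group on the phenyl ring would read like the two methyl groups of compound 1 and compound 3.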